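From methyl to piperidin-1-yl on an aromatic ring

The source may report more compounds than this note shows. Statements on the series, on what has been measured and on what is new or still open speak of the compounds shown alone.

Compound 1 `Cc1ccccc1Nc1nc(NC2CCCCC2)ncc1Cl` gives > 100000 nM (a limit)
Compound 2 `Cc1ccc(Nc2ncc(Cl)c(Nc3ccccc3C)n2)cc1` gives > 100000 nM (a limit)
Compound 3 `Cc1ccccc1Nc1nc(Nc2ccccn2)ncc1Cl` gives 6150 nM

In an ADME assay on L02 cells (Homo sapiens) for inhibition, read by CCK-8 assay, with a stated time of 48 h (on this read-out lower numbers stand for stronger inhibition of growth and higher numbers for weaker inhibition of growth), compound 2 gives > 100000 nM as a limit and not a number. It stands at the limit of > 100000 nM in this assay, at which 2 of the 3 values shown sit, and has no exact place on the scale. Compound 4 `Cc1ccccc1Nc1nc(Nc2ccc(N3CCCCC3)cc2)ncc1Cl` differs from it in one place (piperidin-1-yl in place of methyl on an aromatic carbon): piperidin-1-yl in place of methyl on an aromatic carbon. Among the compounds with values here, no measured step touches that place, since all of them swap the group on a nitrogen. Of these, a step that the two limits leave unreadable from compound 1 to compound 2 can't be read, while an at least 16-fold lower number from compound 1 to compound 3 (1.21 log units; beyond the scatter) and an at least 16-fold lower number from compound 2 to compound 3 (1.21 log units; beyond the scatter) are large. Within the data shown here, compound 3 thus shows, through an at least 16-fold lower number from compound 2 to compound 3 (1.21 log units; beyond the scatter) at that other place, only that values can fall well under the limit. What is expected in this assay is therefore an at least 2.8-fold lower number from compound 2 to compound 4 (0.45 log units; beyond the scatter) toward a lower number, modest in size, and another limit would be no surprise. The estimated value for compound 4 is 35000 nM (expected range 8000 nM to 100000 nM).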

Compound 4, concentration for 50% growth inhibition: 5690 nM
For compound 4 the middle estimate is 6.2-fold (0.79 log units) above the measured one, and the stated range ends above it.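

In this assay, the aromatic carbon holding the methyl of compound 2 proves able to move the number, with piperidin-1-yl there giving an at least 17-fold lower number from compound 2 to compound 4 (1.24 log units; beyond the scatter). Within the data shown here, every earlier readable step changed the group on a nitrogen, so this is the first readable change at this carbon. Compound 2 is only a limit, so the step has a bound and no exact size: the limit of > 100000 nM in this assay, at which 2 of the 4 values shown sit.

From the compounds shown here alone, how a morpholine ring or a carboxylic acid on this carbon would read remains open. So does whether the drop follows the ring or its nitrogen.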